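Adding a Hydroxy Group to the Sulfonamide Phenyl Ring

The source may report more compounds than this note shows. Statements on the series, on what has been measured and on what is new or still open speak of the compounds shown alone.

In an ADME assay on the whole organism for pharmacokinetics, with Homo sapiens as the target (a lower number here means that a smaller share of the oral dose reaches the circulation, a higher number that a larger share of the oral dose reaches the circulation), compound 2 `O=S(=O)(Nc1ccccc1)c1ccc2nc(-c3ccccc3)c(-c3ccccc3)nc2c1` gives 100%, the higher of the two measured numbers. Compound 1 `O=[N+]([O-])c1ccc(NS(=O)(=O)c2ccc3nc(-c4ccccc4)c(-c4ccccc4)nc3c2)cc1`, which carries a nitro group, gives 87.6%. For the measured compounds named here, the only measured step, a number 12.4 percentage points higher from compound 1 to compound 2 (beyond the scatter), shows that removing that group raised the number modestly. Compound 3 `O=S(=O)(Nc1ccc(O)cc1)c1ccc2nc(-c3ccccc3)c(-c3ccccc3)nc2c1` differs from compound 2 by hydroxy in place of hydrogen on an aromatic carbon. A group on this carbon went with a lower number in that one step, so a modest drop is expected here as well, namely a number 15 percentage points lower from compound 2 to compound 3 (beyond the scatter). Compound 3 is therefore estimated at 85%, within 65% to 100%.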

Compound 3, oral bioavailability: 93.9%
Beside the measured number, compound 3's estimate is 8.9 percentage points below it, and the stated range covers the measured number.
By their numbers in this assay, from the lowest: compounds 1, 3 and 2 (each within the scatter of the next, the first and the last beyond it).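

With hydroxy on this carbon, para to a large group, this assay shows a number 6.1 percentage points lower from compound 2 to compound 3 (within the scatter) and, with hydroxy in place of nitro, a number 6.3 percentage points higher from compound 1 to compound 3 (within the scatter) as well. A group on this carbon therefore need not go with a number beyond the scatter: of the two groups shown, only nitro does so against hydrogen. No measurement here explains why these two groups differ. As far as these compounds go, whether an amine or a carboxylic acid on this carbon would stay within the scatter of compound 2 remains open.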